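The compounds below may be only part of what the source reports. "The series", "measured", "known", "first", "only" and "open" are said of these compounds alone.

Working notes on the series. Compound 1 `Cc1cccc(-c2ccc(OC[C@@H]3Cn4ccc(=O)nc4O3)cc2)c1C` and compound 2 `Cc1cccc(-c2ccc(OC[C@@H]3Cn4cc(C)c(=O)nc4O3)cc2)c1C` share one core. Going by the values given here, in a functional assay on HEK293 cells for positive allosteric modulation of metabotropic glutamate receptor 2 (Homo sapiens), read by fluorescence and cAMP accumulation, with a stated time of 5 min (on this read-out lower numbers stand for an effect already at smaller amounts and higher numbers for an effect only at larger amounts of compound), compound 1 gives 330 nM, while compound 2 gives 14 nM, the lowest of the two numbers; the only measured step is a 24-fold lower number from compound 1 to compound 2 (1.37 log units; beyond the scatter), a large one. Compound 3 `CCc1cn2c(nc1=O)O[C@H](COc1ccc(-c3cccc(C)c3C)cc1)C2` carries methyl in place of hydrogen on a saturated chain carbon bound to an aromatic carbon. Among the compounds with values here, no measured step covers a methyl-to-ethyl extension, since a 24-fold lower number from compound 1 to compound 2 (1.37 log units; beyond the scatter) concerns a hydrogen-to-methyl change, so the number for compound 3 is expected to stay close to that of compound 2, with a 1.1-fold higher number from compound 2 to compound 3 (0.03 log units; within the scatter) within the scatter. Compound 3 is estimated at 15 nM, range 5 nM to 50 nM.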

Compound 3, half-maximal effective concentration: 13 nM
Compound 3: the middle estimate sits 1.2-fold (0.06 log units) above what was measured, within the range that was stated.
By their numbers in this assay, from the lowest: compounds 3 and 2 (each within the scatter of the next); then compound 1.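

In this assay, ethyl in place of the methyl gives a 1.1-fold lower number from compound 2 to compound 3 (0.03 log units; within the scatter), so this position takes the one-carbon extension with no change beyond the scatter. The large drop seen with methyl is not specific to methyl: the ethyl group gives a 25-fold lower number from compound 1 to compound 3 (1.40 log units; beyond the scatter), of a size close to the methyl step a 24-fold lower number from compound 1 to compound 2 (1.37 log units; beyond the scatter). No measured data on the compounds bear on why this position tolerates both groups. As far as these compounds go, it stays open whether a longer chain such as propyl or butyl, or a branched one such as isopropyl, keeps the number in this range. From the compounds shown here alone, a hydroxymethyl or an amine at this position is equally open.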